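Swapping 3-chlorophenyl for 4-bromophenyl

A few compounds are considered here, and "the series" means these few. Any claim that something is new, unique, unknown or untested is made for them only; others in the source may bear on it.

In a functional assay on HL-60 cells (Homo sapiens) for antiproliferative activity, read by MTT assay, with a stated time of 72 h (a lower number here means a stronger inhibitor, a higher number a weaker inhibitor), compound 3 (`NC1=NC2(CCSCC2)N(OCCCOc2cccc(Cl)c2)C(N)=N1`) gives 260 nM. That lies within the scatter of compound 1 (`NC1=NC2(CCSCC2)N(OCCCOc2ccc(Cl)c(Cl)c2)C(N)=N1`) at 140 nM and of compound 2 (`CC(C)(C)c1ccc(OCCCON2C(N)=NC(N)=NC23CCSCC3)cc1`) at 280 nM, so these repeat-level differences cannot rank the three compounds. Compound 4 (`NC1=NC2(CCSCC2)N(OCCCOc2ccc(Br)cc2)C(N)=N1`) keeps the shared core and chain of compound 3 but has 4-bromophenyl in place of 3-chlorophenyl on an oxygen on a saturated carbon. For the measured compounds named here, no compound carrying bromine has been measured yet, so the evidence is indirect. Going by the values given here, the one measured step that bears on this change is a 1.9-fold higher number from compound 1 to compound 3 (0.27 log units; within the scatter), with hydrogen in place of chloro on an aromatic carbon, and it stays within the scatter. Altering the halogens on this ring therefore moved this assay little in that single case, and no clear direction can be drawn from it. The expected change is a 1.2-fold lower number from compound 3 to compound 4 (0.07 log units; within the scatter), which would not exceed the scatter. For compound 4 the estimated value is 220 nM, with an expected range from 100 nM to 480 nM.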

Compound 4, half-maximal inhibitory concentration: 350 nM
The estimate for compound 4 lay 1.6-fold (0.20 log units) below the measured number, and the stated range covers the measured number.
By their numbers in this assay, from the lowest: compounds 1, 3, 2 and 4 (each within the scatter of the next, the first and the last beyond it).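

In this assay, there is a 1.3-fold higher number from compound 3 to compound 4 (0.13 log units; within the scatter) when 4-bromophenyl replaces 3-chlorophenyl, and a 1.3-fold higher number from compound 2 to compound 4 (0.10 log units; within the scatter) when bromo replaces tert-butyl, so a bromine on this ring cannot be told apart from either of those arrangements. For the compounds shown here, the one step here that clears the scatter is a 2.5-fold higher number from compound 1 to compound 4 (0.40 log units; beyond the scatter), a modest loss on going from 3,4-dichlorophenyl to 4-bromophenyl, which shows that changes on this aromatic ring can register in this assay, though only just. Nothing measured on these compounds explains that difference.

As far as these compounds go, it remains open whether this ring could carry an amine or a carboxylic acid in place of a halogen or tert-butyl. A longer chain between the ring and the shared core is also untested among the compounds shown here.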